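A few compounds are considered here, and "the series" means these few. Any claim that something is new, unique, unknown or untested is made for them only; others in the source may bear on it.

Compound 1 `Cc1nnc(SCC(=O)c2ccccc2)n1N1C(=O)c2ccccc2C1=O` in a functional assay on PC-3M cells (Homo sapiens) for cytotoxicity, read by MTT assay, with a stated time of 48 h (on this read-out higher numbers stand for weaker inhibition and lower numbers for stronger inhibition), gives > 200000 nM, which is a limit of the assay and not a number.
Compound 2 `Cc1nnc(SCc2ccccc2Cl)n1N1C(=O)c2ccccc2C1=O` in this assay gives > 200000 nM, again a limit of the assay rather than a number.
Compound 3 `CCCc1nnc(SCc2ccccc2Cl)n1N1C(=O)c2ccccc2C1=O` in this assay gives > 200000 nM, also a limit of the assay rather than a number.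

The three measured compounds share one core, and compound 3 differs from compound 2 only by ethyl in place of hydrogen on a saturated chain carbon bound to an aromatic carbon. The step that the two limits leave unreadable from compound 2 to compound 3 therefore cannot be sized, since both values are limits. Compound 1 differs from compound 2 by benzoyl in place of 2-chlorophenyl on a saturated chain carbon bound to a sulfur, and the step that the two limits leave unreadable from compound 2 to compound 1 is hidden in the same way; the evidence for this is the limit of > 200000 nM in this assay, at which 3 of the 3 values shown sit, where every measured value sits.

Compound 4 `CCCc1nnc(SCC(=O)c2ccccc2)n1N1C(=O)c2ccccc2C1=O` is not yet measured. Going by the values given here, it differs from compound 3 by benzoyl in place of 2-chlorophenyl on a saturated chain carbon bound to a sulfur, the same change at the same place as the one from compound 2 to compound 1. Among the compounds with values here, with all measured values at the limit, the only guide is the limit of > 200000 nM in this assay, at which 3 of the 3 values shown sit, and the expectation is that the step that the limit leaves unreadable from compound 3 to compound 4 will again be unreadable rather than a real movement. Compound 4 is therefore expected to give about 300000 nM in this assay, with a likely range from 150000 nM to 1000000 nM, and most probably only a limit will be reported.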

Compound 4, half-maximal inhibitory concentration: > 200000 nM
Compound 4 ended at the assay's limit; the forecaster's own chance of this, stated with the estimate: 90%; the middle value does not contradict the limit.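

Compound 4 sits at the assay's limit, as do compound 1, compound 2 and compound 3, so neither step to compound 4, from compound 3 or from compound 1, can be read: the limit of > 200000 nM in this assay, at which 4 of the 4 values shown sit. The compounds shown leave open whether benzoyl in place of 2-chlorophenyl, or ethyl in place of hydrogen, changes the outcome in this assay at all, and none of the four has a result that is an actual number.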